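The source may hold more compounds than are shown below. What is called first, only, known or untested is meant among the compounds shown, and "the series" means these compounds.

Of the compounds shown here, three sharing one core have so far been tested in an ADME assay on BJ cells (Homo sapiens), read by MTT assay, with a stated time of 72 h (a higher number here means a weaker inhibitor, a lower number a stronger inhibitor), and all of them lie at the weak end of the scale. Compound 1 `CSc1ncnc2c1c(-c1cccs1)cn2[C@@H]1O[C@H](CO)[C@@H](O)[C@H]1O` gives 96900 nM in this measurement. Compound 2 `CSc1ncnc2c1c(-c1ccccc1)cn2[C@@H]1O[C@H](CO)[C@@H](O)[C@H]1O` reads > 100000 nM and that is a limit of the assay, not a number. Compound 3 `CNc1ncnc2c1c(-c1cccs1)cn2[C@@H]1O[C@H](CO)[C@@H](O)[C@H]1O` reads > 100000 nM and that too is a limit. Compound 3 therefore stands at the limit of > 100000 nM in this assay, at which 2 of the 3 values shown sit, and has no exact figure.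

Going by the values given here, compound 4 `C#Cc1cn([C@@H]2O[C@H](CO)[C@@H](O)[C@H]2O)c2ncnc(NC)c12` keeps the methylamino group of compound 3 and carries ethynyl in place of thiophen-2-yl on an aromatic carbon as its one change. The closest measured change also removes thiophen-2-yl and shows an at least 1.0-fold higher number from compound 1 to compound 2 (0.01 log units; that floor lies within the scatter) when phenyl enters. Methylamino in place of methylsulfanyl shows an at least 1.0-fold higher number from compound 1 to compound 3 (0.01 log units; that floor lies within the scatter) on the other side of the core. From the compounds shown here alone, both steps end at the limit, so their true sizes are unknown, and neither involves ethynyl.

With so little to go on, no step beyond the scatter is expected in this assay and compound 4 may well read as a limit too. The estimated change is an at least 1.6-fold lower number from compound 3 to compound 4 (0.22 log units; that floor lies within the scatter) as a slight move toward a stronger number. For compound 4 the expected value is 60000 nM within an estimated range of 8000 nM to 100000 nM for now.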

Compound 4, half-maximal inhibitory concentration: 86000 nM
Beside the measured number, compound 4's estimate is 1.4-fold (0.16 log units) below it, within the range that was stated.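

Until now the group on this aromatic carbon had always been a ring, thiophen-2-yl or phenyl, whereas ethynyl has no ring and 2 heavy atoms where thiophen-2-yl has 5, and in this assay compound 4 gives 86000 nM, an exact figure rather than a limit. From the compounds shown here alone, the change amounts to an at least 1.1-fold lower number from compound 3 to compound 4 (0.06 log units; that floor lies within the scatter), which is only a floor, so its true size remains unknown and nothing beyond the scatter can be claimed for it. A much smaller group without a ring therefore still leaves the compound at the weak end of the scale, where the readings remain crowded: the limit of > 100000 nM in this assay, at which 2 of the 4 values shown sit.

Going by these compounds, it remains open whether an amine, a carboxylic acid or a longer chain on this aromatic carbon would give a number clearly away from that weak end. It is also open whether ethynyl would read the same with methylsulfanyl in place of methylamino on the other side of the shared core, since the compounds shown pair ethynyl only with methylamino.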